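From chlorophenyl to methylphenyl on the amide carbonyl

This account rests on a few compounds, and the source may have more. Where it says the series, first, only, none or still open, it means among the compounds named here.

Going by the values given here, compound 2 `O=C(Nc1cc(-c2ccccc2)nn1-c1ccccc1)c1ccc(Cl)cc1` gives 20 nM in an assay on CHO cells with metabotropic glutamate receptor 5 (Homo sapiens) as the target (on this read-out lower numbers stand for an effect already at smaller amounts and higher numbers for an effect only at larger amounts of compound), the lower of the two numbers so far; compound 1 `O=C(Nc1cc(-c2ccccc2)nn1-c1ccccc1)c1ccccc1F` gives 75 nM in this assay. Among the compounds with values here, the one measured step, a 3.8-fold lower number from compound 1 to compound 2 (0.57 log units; beyond the scatter), concerns a different exchange of aryl groups and bears on the present change only loosely. Compound 3 `Cc1cccc(C(=O)Nc2cc(-c3ccccc3)nn2-c2ccccc2)c1` differs from compound 2 by 3-methylphenyl in place of 4-chlorophenyl on a carbonyl carbon. Without a direct precedent, only a small step is expected, a 2.0-fold higher number from compound 2 to compound 3 (0.30 log units; within the scatter), more likely toward a higher number than a lower one. Compound 3 is therefore estimated at 40 nM, within 15 nM to 110 nM.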

Compound 3, half-maximal effective concentration: 90 nM
Beside the measured number, compound 3's estimate is 2.3-fold (0.35 log units) below it; low and high end bracket the measured number.
By their numbers in this assay, from the lowest: compound 2; then compounds 1 and 3 (each within the scatter of the next).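

In this assay, the exchange of 4-chlorophenyl for 3-methylphenyl on a carbonyl carbon gives a 4.5-fold higher number from compound 2 to compound 3 (0.65 log units; beyond the scatter), so this position responds to a swap between aryl groups of equal heavy-atom count. The exchange of 2-fluorophenyl for 3-methylphenyl gives a 1.2-fold higher number from compound 1 to compound 3 (0.08 log units; within the scatter), which leaves 4-chlorophenyl as the only one of the three aryl groups set apart from the other two. Nothing available explains this difference. The compounds shown leave open whether the difference follows the chlorine or its place on the ring, as both change together. Going by these compounds, how 3-chlorophenyl or 4-methylphenyl would read here also remains open.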